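The compounds below may be only part of what the source reports. "The series", "measured", "known", "first", "only" and "open" are said of these compounds alone.

Compound 1 `CC(=O)c1c(Nc2ccc(F)cc2F)[nH]c2c(F)cc(F)cc2c1=O`: > 25000 nM
Compound 2 `CC(C)C(=O)c1c(Nc2ccc(F)c(F)c2F)[nH]c2c(F)cc(F)cc2c1=O`: > 25000 nM

Both entries come from an ADME assay on Vero cells (Chlorocebus sabaeus) for cytotoxicity; a higher number here means that more compound is tolerated, a lower number that less compound is tolerated. Compound 2 stands at a limit of this assay, > 25000 nM, and this is not a number. Compound 1 also shows a limit, > 25000 nM. Among the compounds with values here, the data therefore hold (the limit of > 25000 nM in this assay, at which 2 of the 2 values shown sit), and no measured step between compounds is available as a guide.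

Compound 3 `CC(C)C(=O)c1c(Nc2ccc(F)cc2F)[nH]c2c(F)cc(F)cc2c1=O` differs from compound 2 in one place, where 2,3,4-trifluorophenyl becomes 2,4-difluorophenyl: hydrogen in place of fluoro on an aromatic carbon. The 2,4-difluorophenyl group of compound 3 is also carried by compound 1, whose value > 25000 nM is a limit. The expected step that the limit leaves unreadable from compound 2 to compound 3 is none beyond the scatter, and another limit is the likeliest report. Compound 3 is estimated at 30000 nM, with an expected range from 18000 nM to 50000 nM.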

Compound 3, half-maximal cytotoxic concentration: > 25000 nM
Compound 3: no number, only a limit (the forecaster's own chance of this, stated with the estimate: 90%); the middle value lies beyond the limit too.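

In this assay, within the data shown here, compound 3 ends at a limit, as compound 1 and compound 2 do, so no step from compound 3 to either of them can be read: the limit of > 25000 nM in this assay, at which 3 of the 3 values shown sit. The compounds shown leave open where their true values lie, and whether hydrogen in place of fluoro, or isopropyl in place of methyl, changes them at all.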